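A few compounds are considered here, and "the series" means these few. Any claim that something is new, unique, unknown or untested is made for them only; others in the source may bear on it.

In a functional assay on NCI/ADR-RES cells (Homo sapiens) for inhibition, read by sulforhodamine B assay, with a stated time of 48 h, tested at 10 uM (on this read-out higher numbers stand for a weaker effect at the one concentration tested and lower numbers for a stronger effect), compound 2, `COc1cc2cc(Oc3ccc(NC(=O)Nc4cccc(C(F)(F)F)c4)cc3)c(C)nc2cc1OC`, gives 6.98%, the lowest of the two numbers obtained; the nearest is compound 1, `COc1cc2cc(Oc3ccc(NC(=O)Nc4ccccc4)cc3)c(C)nc2cc1OC`, which in this assay gives 84.3%. Among the measured compounds shown here, the one measured step, a number 77.3 percentage points lower from compound 1 to compound 2 (beyond the scatter), came with a trifluoromethyl in place of hydrogen on an aromatic carbon. Compound 3, `COc1cc2cc(Oc3ccc(NC(=O)Nc4ccc(Cl)c(C(F)(F)F)c4)cc3)c(C)nc2cc1OC`, differs from compound 2 by chloro in place of hydrogen on an aromatic carbon. For the measured compounds named here, no measured step covers a chloro entering; the trifluoromethyl step only shows that a substituent on this ring can move the number far, and compound 2 already lies near the bottom of the scale, leaving little room for a further fall. Compound 3 is therefore expected to stay close to compound 2, with a step of a number 2 percentage points higher from compound 2 to compound 3 (within the scatter) that is not expected to reach beyond the scatter. In this assay compound 3 is estimated at 9%, within 0% to 30%.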

Compound 3, a percentage reported as activity, at one concentration (the size of the read-out at that concentration, not a potency): 2.01%
Compound 3: the middle estimate sits 7 percentage points above what was measured; measured number inside the range.
By their numbers in this assay, from the lowest: compounds 3 and 2 (each within the scatter of the next); then compound 1.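

Chloro on the aromatic carbon ortho to a trifluoromethyl group and para to a large group comes with a number 5 percentage points lower from compound 2 to compound 3 (within the scatter) in this assay, so this position takes a chloro without the number leaving the scatter around compound 2. The whole change from phenyl to 4-chloro-3-(trifluoromethyl)phenyl comes with a number 82.3 percentage points lower from compound 1 to compound 3 (beyond the scatter), a large step that the chloro cannot be shown to add to, and at this single concentration compound 2 and compound 3 cannot be told apart. Nothing available here accounts for this result.

Open, as far as these compounds go, is whether chloro alone, without the trifluoromethyl group, would move the number away from that of compound 1. Also open, from the compounds shown here alone, is whether a methoxy or a dimethylamino group at this position would hold the number as low as chloro does.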